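Methoxymethoxy to butoxy exchange across two measured pairs

The compounds below may be only part of what the source reports. "The series", "measured", "known", "first", "only" and "open" are said of these compounds alone.

Measured compounds:
compound 1 `COCOc1ccccc1C[C@H]1C(=O)OC[C@@H]1Cc1ccccc1`, 76000 nM
compound 2 `CCCCOc1ccccc1C[C@H]1C(=O)OC[C@@H]1Cc1ccccc1`, 20000 nM
compound 3 `COCOc1cccc(C[C@H]2C(=O)OC[C@@H]2Cc2ccccc2)c1`, 80000 nM

In a functional assay on HL-60 cells (Homo sapiens) for cytotoxicity, read by WST assay, with a stated time of 48 h (a higher number here means that more compound is needed for the effect, a lower number that less compound is needed), compound 1 gives 76000 nM, while compound 2 gives 20000 nM. The change between them is propyl in place of methoxy on a saturated chain carbon bound to an oxygen on an aromatic ring, and it brought a 3.8-fold lower number from compound 1 to compound 2 (0.58 log units; beyond the scatter). Compound 3 gives 80000 nM in this assay, which lies within the scatter of compound 1; the difference between the two cores is not broken down here.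

Compound 4 `CCCCOc1cccc(C[C@H]2C(=O)OC[C@@H]2Cc2ccccc2)c1` is not yet measured. It differs from compound 3 by propyl in place of methoxy on a saturated chain carbon bound to an oxygen on an aromatic ring, the same change as that from compound 1 to compound 2, at the same place in the same printed words. Going by the values given here, only one measured instance of the change exists, so the expectation rests on a single pair. The expected step here is a 3.8-fold lower number from compound 3 to compound 4 (0.58 log units; beyond the scatter), estimated because the same change gave a 3.8-fold lower number from compound 1 to compound 2 (0.58 log units; beyond the scatter). Compound 4 is therefore expected near 21000 nM in this assay. Compound 4 is estimated to fall between 10000 nM and 45000 nM.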

Compound 4, half-maximal effective concentration: 26000 nM
Compound 4: middle estimate off by 1.2-fold (0.09 log units), on the low side; the range from low to high includes it.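

In this assay, exchanging methoxymethoxy for butoxy on the second core gives a 3.1-fold lower number from compound 3 to compound 4 (0.49 log units; beyond the scatter). Going by these compounds alone, the size of the step holds when the change is carried from one core to the other: the same change on two cores in this assay, a 3.8-fold lower number (0.58 log units; beyond the scatter) from compound 1 to compound 2 and a 3.1-fold lower number (0.49 log units; beyond the scatter) from compound 3 to compound 4, 1.2-fold (0.09 log units) apart, within the scatter of two such steps This agreement rests on only two pairs in a single assay, so it supports transfer between these two cores but does not show that the step would hold on any further core, and it gives no reason for the lower number on either core.

The compounds shown leave open whether a longer chain than butoxy, such as hexyloxy, would lower the number further or whether the trend stops at butoxy. They also leave open how an amine or a carboxylic acid at the end of the chain would compare with the butoxy compounds in this assay, and whether the exchange would behave alike on those analogues.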